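Oxane-methyl Amine to Oxazole Amide: Expected Cytotoxicity

This account rests on a few compounds, and the source may have more. Where it says the series, first, only, none or still open, it means among the compounds named here.

Compound 1 `COCCc1ccc(OC(c2ccc(Cl)cc2)c2cnc(NC(=O)OC(C)(C)C)s2)cc1`: > 50000 nM in an ADME assay on HepG2 2.2.15 cells (Homo sapiens) for cytotoxicity (a higher number here means that more compound is tolerated, a lower number that less compound is tolerated), which is a limit of the assay rather than a measured number.
Compound 2 `O=C(Nc1ncc(C(OCc2ccc(Br)cc2)c2ccccc2)s1)c1cccs1`: "not toxic" (no number reported) in this assay.
Compound 3 `Clc1ccc(C(Oc2ccc3cc(Br)ccc3c2)c2cnc(NCC3CCOCC3)s2)cc1`: "not toxic" (no number reported) in this assay.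

Compound 3 thus stands without a single number of its own. Of the other entries, one is the limit of > 50000 nM in this assay, at which 1 of the 3 values shown sits, and one is reported only in words. Compound 4 `Cc1noc(C)c1C(=O)Nc1ncc(C(Oc2ccc3cc(Br)ccc3c2)c2ccc(Cl)cc2)s1` differs from compound 3 by (3,5-dimethyl-1,2-oxazol-4-yl)carbonyl in place of (oxan-4-yl)methyl on a nitrogen on an aromatic ring. No measured step connects any pair of these compounds, so the size of the step in this assay cannot be read from data; no change beyond the usual scatter is expected, and all three measured compounds sit at the tolerated end. For compound 4 the estimated half-maximal cytotoxic concentration is 50000 nM, expected to fall between 20000 nM and 120000 nM, most likely reported again as a limit.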

Compound 4, half-maximal cytotoxic concentration: "not toxic" (no number reported)
No number was reported for compound 4; the estimate stays without a comparison.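

Going by these compounds alone, compound 3 and compound 4 are both reported only in words, as not toxic, so no step between them can be read in this assay. The compounds shown leave open whether swapping (oxan-4-yl)methyl for (3,5-dimethyl-1,2-oxazol-4-yl)carbonyl shifts the half-maximal cytotoxic concentration at all.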